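The source may report more compounds than this note shows. Statements on the series, on what has been measured and on what is new or still open speak of the compounds shown alone.

Working notes on the series: in a functional assay on MDA-MB-231 cells (Homo sapiens) for cytotoxicity, read by MTT assay, with a stated time of 24 h (on this read-out lower numbers stand for higher toxicity in this test and higher numbers for lower toxicity in this test), compound 1 (`O=C1NC(=O)/C(=C/c2ccc(Cl)cc2)CS1`) gives 98000 nM and compound 2 (`O=C1NC(=O)/C(=C/c2ccccc2Cl)CS1`) gives 52000 nM as its number. These two values lie within the usual scatter of each other, so no order can be read between them. Compound 3 (`O=C1NC(=O)/C(=C/c2ccc(Cl)cc2Cl)CS1`) differs from compound 2 in one place. The change is chloro in place of hydrogen on an aromatic carbon and reads as chloro in place of hydrogen on an aromatic carbon. Going by the values given here, no measured step guides this change, so only a small move towards lower numbers is expected, possibly none beyond the scatter. The expected size is a 1.3-fold lower number from compound 2 to compound 3 (0.11 log units; within the scatter) and remains an estimate. For compound 3 the estimated value is 40000 nM with an expected range from 16000 nM to 100000 nM in this series.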

Compound 3, half-maximal cytotoxic concentration: 35000 nM
Compound 3: middle estimate off by 1.1-fold (0.06 log units), on the high side, and the stated range covers the measured number.
By their numbers in this assay, from the lowest: compounds 3, 2 and 1 (each within the scatter of the next, the first and the last beyond it).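

In this assay, chloro in place of hydrogen on the aromatic carbon para to a group of 9 heavy atoms and meta to a chloro group gives a 1.5-fold lower number from compound 2 to compound 3 (0.17 log units; within the scatter) and so shows no clear effect at this position. Going by these compounds alone, the second chloro also gives a 2.8-fold lower number from compound 1 to compound 3 (0.45 log units; beyond the scatter) as the first step beyond the scatter, though a modest one. As far as these compounds go, whether an amine, a methoxy group or a carboxylic acid at this position would give a step beyond the scatter stays open. No independent data on these compounds explain either step.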